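The compounds below may be only part of what the source reports. "The series", "measured", "known", "first", "only" and "open" are said of these compounds alone.

Three compounds sharing one core, each carrying a selenocyanate group and a carbamate, have been tested in a functional assay on HTB-54 cells (Homo sapiens) for cytotoxicity, read by MTT assay, with a stated time of 72 h; a lower number here means a stronger inhibitor of growth, a higher number a weaker inhibitor of growth. Compound 1 `COc1ccc(OC(=O)Nc2ccc([Se]C#N)cc2)cc1` gives 23700 nM, compound 2 `CCCOC(=O)Nc1ccc([Se]C#N)cc1` gives 28900 nM, and compound 3 `Cc1ccc(OC(=O)Nc2ccc([Se]C#N)cc2)cc1` gives 17300 nM. The number for compound 3 is the smallest of the three, yet its gaps to compound 1 and to compound 2 both lie within the scatter, so the three are not distinguishable by this assay. Among the measured compounds shown here, the one step that changes a single place, a 1.4-fold lower number from compound 1 to compound 3 (0.14 log units; within the scatter), also stays within the scatter.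

Compound 4 `N#C[Se]c1ccc(NC(=O)Oc2ccccc2)cc1` differs from compound 3 by hydrogen in place of methyl on an aromatic carbon. For the measured compounds named here, no measured step removes a methyl from this place; the only step that touches it, a 1.4-fold lower number from compound 1 to compound 3 (0.14 log units; within the scatter), exchanged one small group for another and produced no shift beyond the scatter. On that basis the step from compound 3 to compound 4 is expected to be a 1.2-fold higher number from compound 3 to compound 4 (0.06 log units; within the scatter), that is, no change beyond the scatter. Compound 4 is therefore estimated at 20000 nM in this assay, with a range from 8000 nM to 50000 nM.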

Compound 4, concentration for 50% growth inhibition: 26200 nM
Compound 4: the middle estimate sits 1.3-fold (0.12 log units) below what was measured, within the range that was stated.
By their numbers in this assay, from the lowest: compounds 3, 1, 4 and 2 (each within the scatter of the next).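

Taking the methyl off this aromatic carbon in this assay leaves the number within the scatter (a 1.5-fold higher number from compound 3 to compound 4 (0.18 log units; within the scatter)), so hydrogen, the smallest option, can now be compared directly with methyl at this place. Hydrogen also matches methoxy here (a 1.1-fold higher number from compound 1 to compound 4 (0.04 log units; within the scatter)), and the same holds at the other end of the carbamate, where phenyl replaces propyl on the oxygen next to a carbonyl group (a 1.1-fold lower number from compound 2 to compound 4 (0.04 log units; within the scatter)), so none of these changes separates the compounds. No independent measurement bears on these results. Still open, going by these compounds, is whether an amine or a carboxylic acid on this aromatic carbon would move the number beyond the scatter. The same question stands for a longer chain in place of propyl on the oxygen.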